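The source may report more compounds than this note shows. Statements on the series, on what has been measured and on what is new or still open speak of the compounds shown alone.

Measured in a functional assay on HeLa cells (Homo sapiens) for antiproliferative activity, read by sulforhodamine B assay; on this read-out higher numbers stand for weaker inhibition of growth and lower numbers for stronger inhibition of growth:
Compound 1 `CC[C@@H]1O[C@H](COCc2ccccc2)[C@@H](OCc2ccccc2)[C@H](OCc2ccccc2)[C@H]1O`: 19800 nM.
Compound 2 `CC[C@H]1O[C@H](COCc2ccccc2)[C@@H](OCc2ccccc2)[C@H](OCc2ccccc2)[C@H]1O`: > 50000 nM, a limit.
Compound 3 `CCC[C@@H]1O[C@H](CO)[C@@H](O)[C@H](O)[C@H]1O`: > 50000 nM, a limit.

Compound 2 gives > 50000 nM, which is a limit and not a number. Compound 4 `O[C@@H]1[C@@H](OCc2ccccc2)[C@H](OCc2ccccc2)[C@@H](COCc2ccccc2)O[C@@H]1CC1CCCCC1` departs from it by cyclohexyl in place of methyl on a saturated chain carbon bound to a saturated ring carbon, which also reads as ethyl to cyclohexylmethyl. Among the compounds with values here, no measured step changes this group. Within the data shown here, the only measured step, an at least 2.5-fold higher number from compound 1 to compound 2 (0.40 log units; beyond the scatter), comes with the fact that compounds 1 and 2 differ only in the configuration as drawn, and its full size stays open because of the limit of > 50000 nM in this assay, at which 2 of the 3 values shown sit. A modest move towards stronger inhibition of growth is expected because compound 1 reaches 19800 nM with the same atoms and bonds as compound 2. The expected change is an at least 1.6-fold lower number from compound 2 to compound 4 (0.22 log units; that floor lies within the scatter) in this assay, and a reading at the limit is about as likely. For compound 4 the estimated value is 30000 nM, with an expected range of 10000 nM to 50000 nM.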

Compound 4, concentration for 50% growth inhibition: > 50000 nM
Compound 4 was reported as a limit (the forecaster's own chance of this, stated with the estimate: 50%); at least 1.6-fold (0.22 log units) between middle value and limit.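

Compound 2 and compound 4 both stand at a limit of the assay, and the step between them cannot be read. The compounds shown leave open whether cyclohexyl in place of methyl changes growth inhibition at all.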